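This account rests on a few compounds, and the source may have more. Where it says the series, first, only, none or still open, it means among the compounds named here.

Measured compounds:

Compound 1, `O=C(NCc1cc(Cl)ccc1-n1cnnn1)[C@@H]1CC=NN1C(=O)[C@H](O)c1ccccc1`. In an ADME assay on liver for metabolic stability, with Liver microsome (Homo sapiens) as the target, read by LC-MS, using microsomes (a lower number here means slower removal, a higher number faster removal of the compound), compound 1 gives a limit and not a number, < 12 mL.min-1.g-1.
Compound 2, `O=C([C@H](O)c1ccccc1)N1CC[C@@H]2C[C@@]21C(=O)NCc1cc(Cl)ccc1-n1cnnn1`. In this assay compound 2 gives 43 mL.min-1.g-1.
Compound 3, `CC(C)(C)C[C@@H](O)C(=O)N1N=CC[C@H]1C(=O)NCc1cc(Cl)ccc1-n1cnnn1`. In this assay compound 3 gives 22 mL.min-1.g-1.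

The change from compound 1 to compound 3 is neopentyl in place of phenyl on a saturated chain carbon bound to a carbonyl carbon and an oxygen on a saturated carbon. It gave an at least 1.8-fold higher number from compound 1 to compound 3 (0.26 log units; that floor lies within the scatter), with compound 1 sitting at the limit of < 12 mL.min-1.g-1 in this assay, at which 1 of the 3 values shown sits. Compound 2 and compound 4 differ from compound 1 and compound 3 in the core; the difference between the two cores is not broken down here. The values of compound 2 and compound 3 lie within the scatter of one another.

Compound 4, `CC(C)(C)C[C@@H](O)C(=O)N1CC[C@@H]2C[C@@]21C(=O)NCc1cc(Cl)ccc1-n1cnnn1`, is not yet measured in this assay. It differs from compound 2 by neopentyl in place of phenyl on a saturated chain carbon bound to a carbonyl carbon and an oxygen on a saturated carbon, the same change as from compound 1 to compound 3, at the same place.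

The expected step is a 1.5-fold higher number from compound 2 to compound 4 (0.18 log units; within the scatter), resting on the measured step of an at least 1.8-fold higher number from compound 1 to compound 3 (0.26 log units; that floor lies within the scatter) from compound 1, whose floor lies within the scatter. For compound 4 the estimate in this assay is 65 mL.min-1.g-1, expected to fall between 30 mL.min-1.g-1 and 130 mL.min-1.g-1.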

Compound 4, intrinsic clearance in microsomes: 27 mL.min-1.g-1
The estimate for compound 4 lay 2.4-fold (0.38 log units) above the measured number, outside the stated range (below it).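

In this assay, neopentyl in place of phenyl gave a 1.6-fold lower number from compound 2 to compound 4 (0.20 log units; within the scatter). The change therefore does not carry over as one constant step from one core to the other: the same change on two cores in this assay, an at least 1.8-fold higher number (0.26 log units; that floor lies within the scatter) from compound 1 to compound 3 and a 1.6-fold lower number (0.20 log units; within the scatter) from compound 2 to compound 4, at least 2.9-fold (0.46 log units) apart, beyond the scatter of two such steps

Compound 1 gives a limit and not a number, < 12 mL.min-1.g-1, and a single pair on each core does not show why the two steps part or how the change would behave on any further core.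

The compounds shown leave open how a longer chain or an amine would read in this assay on either core, in the same place, on a saturated chain carbon bound to a carbonyl carbon and an oxygen on a saturated carbon.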